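Dropping the fluoro: from compound 3 to compound 4

The compounds below may be only part of what the source reports. "The series", "measured", "known", "first", "only" and "open" are said of these compounds alone.

Three measured compounds share one core and differ only in the group on the outer aromatic ring. Compound 1 `CC#CC(CC(=O)O)c1ccc(OCc2ccc3nc(-c4ccc(C(C)C)cc4)cn3c2)cc1` carries an isopropyl there and gives 528 nM in an assay on isolated protein for agonist activity at Free fatty acid receptor 1 (Homo sapiens); a higher number here means that more compound is needed for the effect, a lower number that less compound is needed. Compound 2 `CC#CC(CC(=O)O)c1ccc(OCc2ccc3nc(-c4ccc(C5CCCCC5)cc4)cn3c2)cc1` carries a cyclohexyl and gives 417 nM. Compound 3 `CC#CC(CC(=O)O)c1ccc(OCc2ccc3nc(-c4ccc(F)cc4)cn3c2)cc1` carries a fluoro and gives 623 nM. Compound 3 holds the highest of the three numbers, yet the steps that lead to it are small: a 1.2-fold higher number from compound 1 to compound 3 (0.07 log units; within the scatter) and a 1.5-fold higher number from compound 2 to compound 3 (0.17 log units; within the scatter), both within the scatter, just as a 1.3-fold lower number from compound 1 to compound 2 (0.10 log units; within the scatter) is. The three values therefore sit together, and no ranking among them can be drawn.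

Compound 4 `CC#CC(CC(=O)O)c1ccc(OCc2ccc3nc(-c4ccccc4)cn3c2)cc1` has not yet been measured. hydrogen in place of fluoro on an aromatic carbon The measured steps swap isopropyl, cyclohexyl and fluoro at this position without moving the number beyond the scatter, which suggests, for these three compounds, that the position tolerates such swaps. Within the data shown here, no measured step involves a hydrogen at this position, so the analyst rests on the three small steps alone and expects no step beyond the scatter, a 1.0-fold lower number from compound 3 to compound 4 (0.00 log units; within the scatter). For compound 4 the estimate is 620 nM, with a range from 300 nM to 1300 nM.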

Compound 4, half-maximal effective concentration: 979 nM
Compound 4: middle estimate off by 1.6-fold (0.20 log units), on the low side; the measured number falls inside the stated range.
By their numbers in this assay, from the lowest: compounds 2, 1, 3 and 4 (each within the scatter of the next, the first and the last beyond it).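

Hydrogen in place of a substituent gives the first step at this position that lies beyond the scatter in this assay (a 2.3-fold higher number from compound 2 to compound 4 (0.37 log units; beyond the scatter)), so the position's apparent tolerance no longer covers every pair of groups. The step is modest, and it is the only one of its kind: the 4-fluorophenyl to phenyl change (a 1.6-fold higher number from compound 3 to compound 4 (0.20 log units; within the scatter)) and the exchange of isopropyl for hydrogen (a 1.9-fold higher number from compound 1 to compound 4 (0.27 log units; within the scatter)) both stay within the scatter, so hydrogen cannot be told apart from fluoro or isopropyl here. The four compounds thus separate only at their two ends, with cyclohexyl and hydrogen as the one pair that can be ranked, and nothing shown gives a reason for that gap.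

The compounds shown leave open how an amine, a carboxylic acid or a longer chain at this place on the ring would read against the hydrogen of compound 4. They also leave open whether the gap between cyclohexyl and hydrogen would persist if the rest of the shared core were changed.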